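Nitro in place of methyl on the shared core

The source may report more compounds than this note shows. Statements on the series, on what has been measured and on what is new or still open speak of the compounds shown alone.

Compound 1 `O=c1ccn(COCCO)c(=O)[nH]1` and compound 2 `Cc1cn(COCCO)c(=O)[nH]c1=O` share one core. In a functional assay on L1210 cells (Mus musculus) for inhibition (a higher number here means a weaker inhibitor, a lower number a stronger inhibitor), compound 1 gives only a limit, > 1000 ug/mL. In this assay compound 2 also gives only a limit, > 1000 ug/mL. The step that the two limits leave unreadable from compound 1 to compound 2 is thus not readable, since (the limit of > 1000 ug/mL in this assay, at which 2 of the 2 values shown sit). Compound 2 stands at that limit with no number beneath it. Compound 3 `O=c1[nH]c(=O)n(COCCO)cc1[N+](=O)[O-]` differs from compound 2 by nitro in place of methyl on an aromatic carbon. No readable measured step bears on this change. Compound 3 is therefore expected to sit near the same limit, estimated at 1000 ug/mL (range 200 ug/mL to 5000 ug/mL). The expected step is a number no higher from compound 2 to compound 3 (the limit leaves the size open).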

Compound 3, concentration for 50% inhibition: > 1000 ug/mL
Compound 3 was reported as a limit; the forecaster's own chance of this, stated with the estimate: 75%; the middle value lies on the limit itself.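

No new step can be read among compound 1, compound 2 and compound 3 in this assay, since all three give only a limit: the limit of > 1000 ug/mL in this assay, at which 3 of the 3 values shown sit. As far as these compounds go, whether hydrogen, methyl or nitro on this aromatic carbon differ at all in inhibition stays open.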